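From Methyl to Dimethylamino: an Expected Shift in Cytotoxicity

This account rests on a few compounds, and the source may have more. Where it says the series, first, only, none or still open, it means among the compounds named here.

Compound 1 `CC(=O)OC[C@H]1O[C@@H](n2cc(Cn3cc(/C=C4/C(=O)Nc5ccccc54)c4ccccc43)nn2)[C@H](OC(C)=O)[C@@H](OC(C)=O)[C@@H]1OC(C)=O`, in a functional assay on DU-145 cells (Homo sapiens) for cytotoxicity, read by sulforhodamine B assay, with a stated time of 48 h (a lower number here means a stronger inhibitor, a higher number a weaker inhibitor), gives only a limit, > 200000 nM.
Compound 2 `CC(=O)OC[C@H]1O[C@@H](n2cc(CN3C(=O)/C(=C/c4ccc(C)cc4)c4ccccc43)nn2)[C@H](OC(C)=O)[C@@H](OC(C)=O)[C@@H]1OC(C)=O` gives 9300 nM.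
Compound 3 `CC(=O)OC[C@H]1O[C@@H](n2cc(CN3C(=O)/C(=C\c4ccc(C)cc4)c4ccccc43)nn2)[C@H](OC(C)=O)[C@@H](OC(C)=O)[C@@H]1OC(C)=O` gives 9400 nM.

Compound 3 stands with the highest number of the two numbers shown, yet its nearest neighbour is compound 2, and the step of a 1.0-fold higher number from compound 2 to compound 3 (0.00 log units; within the scatter) lies within the scatter. That step rests on (the fact that compounds 2 and 3 differ only in the configuration as drawn), so it says nothing about the substituent on the aryl ring. Among the measured compounds shown here, the value of compound 1 is a limit, as the limit of > 200000 nM in this assay, at which 1 of the 3 values shown sits, makes plain, and offers no measure of a step either.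

Compound 4 `CC(=O)OC[C@H]1O[C@@H](n2cc(CN3C(=O)/C(=C\c4ccc(N(C)C)cc4)c4ccccc43)nn2)[C@H](OC(C)=O)[C@@H](OC(C)=O)[C@@H]1OC(C)=O` differs from compound 3 by dimethylamino in place of methyl on an aromatic carbon. For the measured compounds named here, none of the measured steps concerns a change at this position, so there is no measured guide to the size or direction of the effect. The expectation for compound 4 is therefore a number close to that of compound 3, with a wide range to cover the unknown, and the step of a 1.3-fold lower number from compound 3 to compound 4 (0.13 log units; within the scatter) is estimated to remain modest. Compound 4 is expected to give about 7000 nM, between 1500 nM and 30000 nM.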

Compound 4, half-maximal inhibitory concentration: 10100 nM
Compound 4: middle estimate off by 1.4-fold (0.16 log units), on the low side; low and high end bracket the measured number.
By their numbers in this assay, from the lowest: compounds 2, 3 and 4 (each within the scatter of the next). At a limit, above all of these: compound 1.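

In this assay, among the compounds shown here, this is the first measured change to the substituent on the aromatic ring, and it gives a 1.1-fold higher number from compound 3 to compound 4 (0.03 log units; within the scatter) with no shift beyond the scatter. The earlier pair differed only in how a double bond was drawn, so it could not speak to this position, whereas here the exchange of 4-methylphenyl for 4-(dimethylamino)phenyl shows that the reading holds when one heavy atom gives way to three and a hydrogen-bond acceptor enters where methyl had none. Nothing at hand gives a measured property of either group that would account for this flat step.

The compounds shown leave open whether a different group at this place, such as a carboxylic acid, a fluorine atom or a longer alkyl chain, would carry the number beyond the scatter, and whether an amine with a free hydrogen, such as methylamino, would read like dimethylamino. They also leave open whether the dimethylamino group gives the same reading with the double bond drawn as in compound 2.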